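Swapping an ethyl ester for a free acid

A few compounds are considered here, and "the series" means these few. Any claim that something is new, unique, unknown or untested is made for them only; others in the source may bear on it.

Compound 1 `CCOC(=O)/C=C/c1ccncc1-c1ccc2[nH]ccc2c1` gives 7440 nM
Compound 2 `CCOC(=O)/C=C/c1ccncc1-c1ccc2ccccc2c1` gives 5380 nM

In a functional assay on A549 cells (Homo sapiens) for inhibition, read by sulforhodamine B assay, with a stated time of 72 h (on this read-out lower numbers stand for stronger inhibition of growth and higher numbers for weaker inhibition of growth), compound 1 reads (7440 nM) and compound 2 reads (5380 nM), two numbers that lie within the usual scatter of each other. Compound 3 (`O=C(O)/C=C/c1ccncc1-c1ccc2[nH]ccc2c1`) is compound 1 with hydrogen in place of ethyl on an oxygen next to a carbonyl group, so that ethoxycarbonyl becomes carboxy. Among the compounds with values here, no measured pair here shows what this change does, so the expectation rests on the structural change alone and stays uncertain. A move to a higher number, meaning weaker inhibition of growth, is expected, probably beyond the scatter. The expected size is (a 2.7-fold higher number from compound 1 to compound 3 (0.43 log units; beyond the scatter)). For compound 3 the estimated value is 20000 nM (range 7000 nM to 60000 nM).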

Compound 3, concentration for 50% growth inhibition: > 10000 nM
Compound 3 ended at the assay's limit; the forecaster's own chance of this, stated with the estimate: 25%; the middle value is on the limit's open side.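

This is the first step shown for this change on the oxygen next to the carbonyl group. In this assay, turning ethoxycarbonyl into carboxy gives a step with only a lower bound (an at least 1.3-fold higher number from compound 1 to compound 3 (0.12 log units; that floor lies within the scatter)), so its true size is not fixed and the floor alone does not separate the two compounds. Compound 3 has no exact number, only a limit of the assay: the limit of > 10000 nM in this assay, at which 1 of the 3 values shown sits.

Going by these compounds, it remains open whether a methyl group or a longer chain such as propyl in place of ethyl on this oxygen would keep the reading of compound 1 or move it. On these data alone, it is also open whether the same swap of ethyl for hydrogen on compound 2 would end at the same limit.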